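The source may report more compounds than this note shows. Statements on the series, on what has been measured and on what is new or still open speak of the compounds shown alone.

Series notes, step from compound 1 to compound 4.

Compound 1 `COc1cc(/C=C2\CCC/C(=C\c3ccc(F)c(F)c3)C2=O)cc(OC)c1OC` is the reference point. Among the compounds with values here, in an ADME assay on NHDF cells (Homo sapiens) for cytotoxicity (on this read-out higher numbers stand for weaker inhibition and lower numbers for stronger inhibition), compound 1 gives 11100 nM, the highest of the three numbers measured so far. Compound 2 `COc1cc(/C=C2\CCC/C(=C\c3ccc(O)c(O)c3)C2=O)cc(OC)c1OC` gives 9000 nM in this assay; the step is a 1.2-fold lower number from compound 1 to compound 2 (0.09 log units; within the scatter). Compound 3 `COc1cc(/C=C2\CCC/C(=C\c3ccccc3F)C2=O)cc(OC)c1OC` gives 4000 nM in this assay; the step is a 2.8-fold lower number from compound 1 to compound 3 (0.44 log units; beyond the scatter). Between the two analogues the step is a 2.3-fold lower number from compound 2 to compound 3 (0.35 log units; beyond the scatter).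

Compound 4 `COc1cc(/C=C2\CCC/C(=C\c3cccc(O)c3)C2=O)cc(OC)c1OC` has not yet been measured. Its change from compound 1 is 3-hydroxyphenyl in place of 3,4-difluorophenyl on a double-bonded chain carbon bound to a double-bonded ring carbon. The measured step that bears most on it is the one in which 3,4-dihydroxyphenyl replaced 3,4-difluorophenyl at the same place, namely a 1.2-fold lower number from compound 1 to compound 2 (0.09 log units; within the scatter), which stayed within the scatter. The step in which 2-fluorophenyl entered, a 2.8-fold lower number from compound 1 to compound 3 (0.44 log units; beyond the scatter), was modest but concerns a different replacement and is less directly comparable. For compound 4 in this assay a step of about a 1.2-fold lower number from compound 1 to compound 4 (0.07 log units; within the scatter) is therefore expected, not beyond the scatter. The value of compound 4 in this assay is estimated at 9500 nM, with a range from 4500 nM to 20000 nM.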

Compound 4, half-maximal inhibitory concentration: 25300 nM
The estimate for compound 4 lay 2.7-fold (0.43 log units) below the measured number, and the stated range ends below it.
By their numbers in this assay, from the lowest: compound 3; then compounds 2 and 1 (each within the scatter of the next); then compound 4.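

In this assay this position can move the number upward as well as downward: 3-hydroxyphenyl in place of 3,4-difluorophenyl gives a 2.3-fold higher number from compound 1 to compound 4 (0.36 log units; beyond the scatter) whereas the earlier replacements of 3,4-difluorophenyl either stayed within the scatter or lowered the number. The result for 3,4-dihydroxyphenyl therefore does not carry over to 3-hydroxyphenyl, since hydrogen in place of hydroxy on an aromatic carbon gives a 2.8-fold higher number from compound 2 to compound 4 (0.45 log units; beyond the scatter) and the change from 2-fluorophenyl to 3-hydroxyphenyl gives a 6.3-fold higher number from compound 3 to compound 4 (0.80 log units; beyond the scatter) which places these two groups at the ends of the measured numbers. Nothing available explains why the single hydroxy gives a higher number than the other groups at this place.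

Still open, going by these compounds, is whether the higher number goes with the hydroxy itself or with the loss of both fluorines from the phenyl ring. On these data alone, it is also open how an amine or a carboxylic acid on the phenyl ring at this place would compare with 3-hydroxyphenyl in this assay and whether either would follow the hydroxy or the fluorine compounds.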